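Chloro on the pyridine of compound 2: expected clearance

The source may report more compounds than this note shows. Statements on the series, on what has been measured and on what is new or still open speak of the compounds shown alone.

Three amides have been measured in an ADME assay (liver) for metabolic stability, with Liver microsome (Homo sapiens) as the target, read by LC-MS, using microsomes, with a stated time of 60 min, tested at 1 uM; a lower number here means slower removal, a higher number faster removal of the compound. Compound 1 `Cc1cc(Br)ccc1C(=O)Nc1ccccn1` gives 97 uL/min, compound 2 `Cc1c(F)cccc1C(=O)Nc1ccccn1` gives 58 uL/min, and compound 3 `Cc1ccccc1C(=O)Nc1cccc(F)n1` gives 191 uL/min. Compound 2 stands at the lowest of the three numbers, but the gap to compound 1 lies within the usual scatter, and only the gap to compound 3 lies beyond it. Compound 4 `Cc1c(F)cccc1C(=O)Nc1cc(Cl)ccn1` differs from compound 2 by chloro in place of hydrogen on an aromatic carbon. Going by the values given here, no measured pair here isolates that change, so nothing shows its direction; the expectation is a step from compound 2 to compound 4 of a 1.2-fold higher number from compound 2 to compound 4 (0.08 log units; within the scatter) in this assay, not clearly beyond the scatter. Compound 4 is therefore estimated at 70 uL/min, within 35 uL/min to 140 uL/min.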

Compound 4, intrinsic clearance in a liver preparation (reported as CLH), per the amount of preparation that the assay uses in the Liver microsome assay: 254 uL/min
Compound 4: the middle estimate sits 3.6-fold (0.56 log units) below what was measured; measured number above the stated range.
By their numbers in the Liver microsome assay, from the lowest: compounds 2, 1, 3 and 4 (each within the scatter of the next, the first and the last beyond it).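

In the Liver microsome assay chloro in place of hydrogen on this aromatic carbon, opposite the ring nitrogen, brings a 4.4-fold higher number from compound 2 to compound 4 (0.64 log units; beyond the scatter) and so gives the first measured sign that this position responds to the change, in the direction of faster removal. In a physicochemical assay for lipophilicity, read by HPLC, at pH 7.4 (a higher number here means a more lipophilic compound, a lower number a more polar compound), compound 2 gives 2.6 and compound 4 gives 2.3 and the two lie within the scatter of each other. No evidence at hand accounts for the step in removal.

From the compounds shown here alone, whether a methoxy group or an amine on this same carbon would bring a step of similar size stays open. So does whether chloro would do the same on a core other than that of compound 2.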